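This account rests on a few compounds, and the source may have more. Where it says the series, first, only, none or still open, it means among the compounds named here.

Compound 1 `c1cc(OCc2ccc(-c3nn[nH]n3)cc2)cc(OCc2ccc3ccccc3n2)c1` is the point of reference. In an assay on isolated protein for binding affinity to cysteinyl leukotriene receptor 1 (Cavia porcellus) (a lower number here means a stronger inhibitor, a higher number a weaker inhibitor), compound 1 gives 10 nM. Compound 2 `COc1cc(-c2nn[nH]n2)ccc1COc1cccc(OCc2ccc3ccccc3n2)c1` differs from it by methoxy in place of hydrogen on an aromatic carbon; in this assay compound 2 gives 4.3 nM, and the step of a 2.3-fold lower number from compound 1 to compound 2 (0.37 log units; beyond the scatter) lies beyond the usual scatter. Compound 3 `c1cc(COc2ccc(-c3nn[nH]n3)cc2)cc(OCc2ccc3ccccc3n2)c1` is made of the same atoms as compound 1 joined differently, and the difference between the two cores is not broken down here. In this assay compound 3 gives 2.9 nM. Against compound 1 this gap lies beyond the scatter, whereas the values of compound 2 and compound 3 fall within the scatter of each other, so no order between those two can be claimed.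

Compound 4 `COc1cc(-c2nn[nH]n2)ccc1OCc1cccc(OCc2ccc3ccccc3n2)c1` has not yet been measured. Relative to compound 3 it carries methoxy in place of hydrogen on an aromatic carbon. The surroundings of this change read word for word as those of the change from compound 1 to compound 2, so it is the same change made again, now on the core of compound 3; it appears in two pairs among the four compounds. The expectation rests on that one measured instance, because a 2.3-fold lower number from compound 1 to compound 2 (0.37 log units; beyond the scatter) shows a modest gain on a closely related core. A gain of similar or somewhat smaller size is expected for compound 4, estimated as a 1.8-fold lower number from compound 3 to compound 4 (0.26 log units; within the scatter). Compound 4 is therefore expected to give about 1.6 nM in this assay. Among the measured compounds shown here, for compound 4 the likely range is estimated to run from 0.7 nM to 4 nM, the width reflecting that only one earlier step supports it.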

Compound 4, inhibition constant: 16 nM
Beside the measured number, compound 4's estimate is 10-fold (1.00 log units) below it, outside the stated range (above it).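

Among the compounds shown here, on the core of compound 3, methoxy in place of hydrogen on an aromatic carbon gives a 5.5-fold higher number from compound 3 to compound 4 (0.74 log units; beyond the scatter) in this assay, so the change runs in the opposite direction to its one earlier instance on the core of compound 1. The two instances differ in direction and by more than repeated measurements would be expected to explain: the same change on two cores in this assay, a 2.3-fold lower number (0.37 log units; beyond the scatter) from compound 1 to compound 2 and a 5.5-fold higher number (0.74 log units; beyond the scatter) from compound 3 to compound 4, 13-fold (1.11 log units) apart, beyond the scatter of two such steps This shows that, across these two pairs, the effect of the methoxy depends on the core that carries it, so a step measured on one core could not be carried over to the other; it does not show which difference between the cores is responsible, and two pairs give no general rule for the series.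

The compounds shown leave open whether a smaller or larger group at the same place, such as fluorine, hydroxyl or ethoxy, would also split between the two cores in this way. They also leave open whether the split would persist with a carboxylic acid in place of the 2H-tetrazol-5-yl group, or with the methoxy on another carbon of the same ring.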